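Aryl for oxazole on a shared core: cytotoxicity

The compounds below may be only part of what the source reports. "The series", "measured", "known", "first", "only" and "open" are said of these compounds alone.

Compound 2 `N#CCCCn1c(Cn2c(=O)n(-c3ncco3)c3ccncc32)cc2cc(Cl)ccc21` was tested in an ADME assay on HeLa cells (Homo sapiens) for cytotoxicity, read by ATP content, with a stated time of 3 days; a lower number here means that less compound is tolerated, a higher number that more compound is tolerated. In this assay compound 2 returns only a limit, > 50000 nM, not a number. Compound 1 `CS(=O)(=O)CCCn1c(Cn2c(=O)n(C3CC3)c3ccncc32)cc2cc(Cl)ccc21` likewise returns only a limit, > 50000 nM. Both measured values thus stand at the limit of > 50000 nM in this assay, at which 2 of the 2 values shown sit. Compound 3 `COc1ccc(-n2c(=O)n(Cc3cc4cc(Cl)ccc4n3CCCC#N)c3cnccc32)cc1C` has not been measured; it differs from compound 2 in one place: 4-methoxy-3-methylphenyl in place of 1,3-oxazol-2-yl on an aromatic nitrogen. Going by the values given here, no step between measured compounds exists to show how such a change acts here, so the step of a number no higher from compound 2 to compound 3 (the limit leaves the size open) is expected to be none beyond the scatter. Compound 3 is expected to give 50000 nM, within 20000 nM to 100000 nM, most likely again as a limit.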

Compound 3, half-maximal cytotoxic concentration: > 50000 nM
Compound 3 ended at the assay's limit; the forecaster's own chance of this, stated with the estimate: 75%; the middle value sits exactly at the limit.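

In this assay, going by these compounds alone, compound 2 and compound 3 both return only a limit, so no step between them can be read. The compounds shown leave open how 4-methoxy-3-methylphenyl and 1,3-oxazol-2-yl compare in this read-out.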